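The source may hold more compounds than are shown below. What is called first, only, known or untested is meant among the compounds shown, and "the series" means these compounds.

Measured so far:
- compound 1, `CCO[C@]1(c2ccc(OCc3c(-c4c(Cl)cccc4Cl)noc3C3CC3)cc2Cl)C[C@H](c2cccc(C(=O)O)c2)C1`: 94%
- compound 2, `CC(C)n1nc(C(=O)O)cc1C1CC1c1ccc(OCc2c(-c3c(Cl)cccc3Cl)noc2C2CC2)cc1Cl`: 102%
- compound 3, `O=C(O)c1cccc([C@H]2C[C@](OCCO)(c3ccc(OCc4c(-c5c(Cl)cccc5Cl)noc4C4CC4)cc3Cl)C2)c1`: 97%

All three values come from an assay on isolated protein for agonist activity at Bile acid receptor (Homo sapiens), read by FRET; on this read-out higher numbers stand for larger maximal responses and lower numbers for smaller maximal responses. Compound 2 gives the highest of the three numbers, but its gap to compound 3 and its gap to compound 1 both lie within the scatter, so no order among the three can be read from these data. For the measured compounds named here, the only single-point step among the measured compounds is a number 3 percentage points higher from compound 1 to compound 3 (within the scatter), also within the scatter; it does not touch the cyclopropane-linked acid arm and bears on the present question only in showing that the read-out has so far been flat across the series.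

Compound 4, `O=C(O)c1ccc(C2CC2c2ccc(OCc3c(-c4c(Cl)cccc4Cl)noc3C3CC3)cc2Cl)cn1`, differs from compound 2 by 6-carboxypyridin-3-yl in place of 3-carboxy-1-isopropyl-1H-pyrazol-5-yl on a saturated ring carbon. Going by the values given here, no measured step changes this acid-bearing group, so nothing directly informs the size of the move. Given that every measured compound lands near the top of the range, the expectation for this assay is a step of a number 6 percentage points lower from compound 2 to compound 4 (within the scatter), that is, none beyond the scatter. Compound 4 is therefore estimated at 96%, with a range from 78% to 110%.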

Compound 4, largest response reached (reported as efficacy), in percent of the reference or control that the assay uses: 101%
Beside the measured number, compound 4's estimate is 5 percentage points below it; measured number inside the range.
By their numbers in this assay, from the lowest: compounds 1, 3, 4 and 2 (each within the scatter of the next).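

In this assay, for the compounds shown here, 6-carboxypyridin-3-yl in place of 3-carboxy-1-isopropyl-1H-pyrazol-5-yl on a saturated ring carbon of the three-membered ring gives a number 1 percentage points lower from compound 2 to compound 4 (within the scatter), the only step read at this position. Here, the maximal response does not separate a five-membered aromatic ring with 2 hetero atoms from a six-membered aromatic ring with 1 hetero atom, each carrying a carboxy group, and the isopropyl group of compound 2 can go without a step beyond the scatter. No supporting measurement is available to explain this result.

As far as these compounds go, both groups carry a carboxylic acid, so what a primary amide or an unsubstituted phenyl ring would do at this position remains open. Only maximal responses are shown, which leaves open how this change affects the concentration needed to reach them.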